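Series notes: aromatic substituent on the saturated ring carbon

The source may report more compounds than this note shows. Statements on the series, on what has been measured and on what is new or still open speak of the compounds shown alone.

Measured so far:
compound 1 `COC(=O)C1=C(C)N=C(C)/C(=C(\O)OC)C1c1ccccc1N` — 39800 nM
compound 2 `COC(=O)C1=C(C)N=C(C)/C(=C(\O)OC)C1c1ccccc1C(F)(F)F` — 1.51 nM
compound 3 `COC(=O)C1=C(C)N=C(C)/C(=C(\O)OC)C1c1cc(C)ccc1C` — 100 nM

In a functional assay (muscle tissue) with Cavia porcellus as the target (a higher number here means that more compound is needed for the effect, a lower number that less compound is needed), compound 1 stands highest of the three numbers recorded so far; the nearest is compound 3 and the furthest is compound 2, both well beyond the scatter.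

The step under consideration goes from compound 1 to compound 4 `COC(=O)C1=C(C)N=C(C)/C(=C(\O)OC)C1c1ccccc1C`, which is not yet measured. The change is methyl in place of amino on an aromatic carbon. Both recorded steps out of compound 1 bear on it. Swapping the amino for trifluoromethyl gave a 26000-fold lower number from compound 1 to compound 2 (4.42 log units; beyond the scatter). Replacing 2-aminophenyl by 2,5-dimethylphenyl gave a 400-fold lower number from compound 1 to compound 3 (2.60 log units; beyond the scatter). Compound 4 shares the methyl ortho to a large group with compound 3 but lacks the second methyl, and shares with compound 2 the loss of the amino group and its hydrogen-bond donor and acceptor. Both precedents point the same way, so a large fall in the number is expected in this assay, likely nearer the size seen for compound 3 than for compound 2, as only the two-methyl analogue is a direct reference.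

For compound 4 a value of 250 nM is estimated, within 30 nM to 2000 nM, which is expected to correspond to a 160-fold lower number from compound 1 to compound 4 (2.20 log units; beyond the scatter).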

Compound 4, half-maximal effective concentration: 6.03 nM
Estimate against measurement, compound 4: 41-fold (1.62 log units) above; the whole stated range lies above it.
By their numbers in this assay, from the lowest: compound 2; then compound 4; then compound 3; then compound 1.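

In this assay, methyl in place of amino on an aromatic carbon, ortho to a large group, gives a 6600-fold lower number from compound 1 to compound 4 (3.82 log units; beyond the scatter), so leaving the 2-aminophenyl group for 2-methylphenyl is enough on its own to produce a large fall in the number. Hydrogen in place of methyl on an aromatic carbon gives a 17-fold lower number from compound 3 to compound 4 (1.22 log units; beyond the scatter), so the additional methyl of the 2,5-dimethylphenyl group goes with a higher number in this series and is not needed for the fall. Methyl in place of trifluoromethyl gives a 4.0-fold higher number from compound 2 to compound 4 (0.60 log units; beyond the scatter), a modest step though beyond the scatter, so most of the fall seen on leaving the amino group does not depend on trifluoromethyl and is reached with a plain methyl.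

Nothing at hand accounts for the size of any of these steps.
Also open, from the compounds shown here alone, is how a chloro, methoxy or hydroxyl group or a longer chain such as ethyl would compare with methyl and trifluoromethyl on this aromatic carbon, and whether the amino compound's high number is specific to an amine or shared by other groups there.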